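Triazole sulfonamide series: aryl swap on the triazole nitrogen

The source may report more compounds than this note shows. Statements on the series, on what has been measured and on what is new or still open speak of the compounds shown alone.

The series shares one core and varies the aryl group on the triazole nitrogen. Compound 1 `Cc1ccccc1-n1cc(-c2ccc(NS(=O)(=O)c3c[nH]c(=O)[nH]c3=O)cc2)nn1` is recorded in an ADME assay on GES1 cells (Homo sapiens) for cytotoxicity, read by MTT assay, with a stated time of 24 h (a lower number here means that less compound is tolerated, a higher number that more compound is tolerated), as "not toxic" (no number reported), a description with no number behind it. Going by the values given here, compound 2 `Cc1cccc(-n2cc(-c3ccc(NS(=O)(=O)c4c[nH]c(=O)[nH]c4=O)cc3)nn2)c1` gives in this assay a value of 28300 nM, the only number in the set. Compound 3 `Cc1ccc(-n2cc(-c3ccc(NS(=O)(=O)c4c[nH]c(=O)[nH]c4=O)cc3)nn2)cc1` is again recorded in this assay as "not toxic" (no number reported), so compound 3 stands without a single number, alongside compound 1 in the same position. Among the compounds with values here, the three measured compounds differ from one another in where the methyl sits on the phenyl ring, and no step between them can be sized, since two of the three entries carry no number.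

Compound 4 `O=c1[nH]cc(S(=O)(=O)Nc2ccc(-c3cn(-c4cccc(F)c4)nn3)cc2)c(=O)[nH]1` is not yet measured. The change from compound 3 is 3-fluorophenyl in place of 4-methylphenyl on an aromatic nitrogen. Within the data shown here, with no numbered step, and the one numbered compound 2 at 28300 nM, a step beyond the scatter is not expected in either direction; compound 4 may again return only a description rather than a number. Compound 4 is expected in this assay at about 30000 nM, with a range from 10000 nM to 100000 nM.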

Compound 4, half-maximal cytotoxic concentration: "not toxic" (no number reported)
Compound 4: no number reported; no gap can be computed for the estimate.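

In this assay, going by these compounds alone, compound 4, like compound 3, carries only a description and no number, so no step between them can be read. No measured evidence bears on this result. Going by these compounds, what remains open is how compound 1, compound 3 and compound 4 would compare numerically with compound 2 at 28300 nM in this series.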